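The source may hold more compounds than are shown below. What is called first, only, known or untested is meant among the compounds shown, and "the series" means these compounds.

Measured so far:
- Compound 1, `Cc1cccc(C(=O)Nc2cccc(-c3oc4cc(-c5ccc(F)cc5)ccc4c(=O)c3O)c2)c1`: 2840 nM
- Compound 2, `COc1cc(OC)cc(C(=O)Nc2cccc(-c3oc4cc(-c5ccc(F)cc5)ccc4c(=O)c3O)c2)c1`: 4040 nM

In a functional assay on MDA-MB-231 cells (Homo sapiens) for antiproliferative activity, read by CCK-8 assay, with a stated time of 72 h (a higher number here means a weaker inhibitor, a lower number a stronger inhibitor), compound 1 gives the lowest of the two numbers; compound 2 sits close by, with a 1.4-fold higher number from compound 1 to compound 2 (0.15 log units; within the scatter), so the two are not distinguished by this assay. Compound 3, `O=C(Nc1cccc(-c2oc3cc(-c4ccc(F)cc4)ccc3c(=O)c2O)c1)c1ccc(-c2ccccc2)cc1`, has not been measured. Compared with compound 1 the difference is 4-phenylphenyl in place of 3-methylphenyl on a carbonyl carbon.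

Within the data shown here, the only measured step, 3,5-dimethoxyphenyl in place of 3-methylphenyl on a carbonyl carbon, changes the same part of the molecule and stayed within the scatter. Among the measured compounds shown here, it does not involve 4-phenylphenyl, so no measured step speaks directly to this change. With nothing pointing either way, compound 3 is expected to land near compound 1, with a 1.1-fold higher number from compound 1 to compound 3 (0.02 log units; within the scatter), and any real shift would have to be seen in the measurement. The estimate for compound 3 is 3000 nM, in the range 1200 nM to 7500 nM.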

Compound 3, half-maximal inhibitory concentration: 63200 nM
For compound 3 the middle estimate is 21-fold (1.32 log units) below the measured one; measured number above the stated range.
By their numbers in this assay, from the lowest: compounds 1 and 2 (each within the scatter of the next); then compound 3.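

In this assay, this position on the carbonyl carbon proves sensitive to what it carries: putting 4-phenylphenyl in place of 3-methylphenyl gives a 22-fold higher number from compound 1 to compound 3 (1.35 log units; beyond the scatter) and a clearly weaker inhibitor, while putting it in place of 3,5-dimethoxyphenyl gives a 16-fold higher number from compound 2 to compound 3 (1.19 log units; beyond the scatter) and the same outcome. The earlier pair stayed within the scatter, so only now is it visible that a change here can move the number far, with the entering group carrying 2 six-membered aromatic rings of carbon only where 3-methylphenyl carries one. Nothing available explains why this change goes with the weaker number. Still open, from the compounds shown here alone, is how far smaller or different groups at this position would shift the number, such as an unsubstituted phenyl or a plain methyl. A phenyl ring bearing an amine or a carboxylic acid is equally untested among the compounds shown here.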